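The source may report more compounds than this note shows. Statements on the series, on what has been measured and on what is new or still open speak of the compounds shown alone.

Measured so far:
Compound 1 `O=C1O[C@H]([C@@H](O)Cn2cc(-c3cc(F)cc(F)c3)nn2)C(OCc2ccccc2)=C1OCc1ccccc1`, tested in an ADME assay on HFF cells (Homo sapiens) for cytotoxicity, read by MTT assay, with a stated time of 72 h; on this read-out higher numbers stand for weaker inhibition and lower numbers for stronger inhibition: > 100000 nM, a limit of the assay rather than a number.
Compound 2 `O=C1O/C(=C\Cn2cc(-c3cc(C(F)(F)F)cc(C(F)(F)F)c3)nn2)C(OCc2ccccc2)=C1OCc1ccccc1`, tested in this assay: > 100000 nM, again a limit of the assay.

Compound 1 stands where the assay stops reporting numbers: its value is a limit, and nothing more exact is known. Compound 2 sits at the same limit, and the limit of > 100000 nM in this assay, at which 2 of the 2 values shown sit, sums up both results. Among the compounds with values here, no step between measured compounds can be drawn from two limits, so the two values together say only that neither compound showed measurable toxicity toward the cells within the tested range.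

Compound 3 `O=C1O[C@H]([C@@H](O)Cn2cc(-c3ccc(Br)cc3)nn2)C(OCc2ccccc2)=C1OCc1ccccc1` differs from compound 1 in one place: 4-bromophenyl in place of 3,5-difluorophenyl on an aromatic carbon. The rest of the shared core is untouched. The step of a number no higher from compound 1 to compound 3 (the limit leaves the size open) is expected to be none beyond the scatter, because compound 1 already sits at the limit of > 100000 nM in this assay, at which 2 of the 2 values shown sit, and the change on the five-membered aromatic ring with 3 nitrogen is a single exchanged ring. For compound 3 the estimate is 100000 nM, in a range from 40000 nM to 300000 nM, and it is expected that the assay will most likely again report only a limit.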

Compound 3, half-maximal inhibitory concentration: 5100 nM
For compound 3 the middle estimate is 20-fold (1.29 log units) above the measured one, and the stated range ends above it.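

This position is not indifferent in this assay: placing 4-bromophenyl in place of 3,5-difluorophenyl on an aromatic carbon of the five-membered aromatic ring with 3 nitrogen gives an at least 19-fold lower number from compound 1 to compound 3 (1.29 log units; beyond the scatter). The group held there can therefore decide whether toxicity toward the cells appears within the tested range, even with the rest of the shared core untouched. Compound 1 supplies only a limit, so the full size of the step stays open: the limit of > 100000 nM in this assay, at which 2 of the 3 values shown sit.

The compounds shown leave open whether the step follows from the arrival of the bromine or from the loss of the two fluorines, since this single exchange changes both at once. They also leave open how a plain phenyl, a 4-chlorophenyl or a phenyl carrying an amine would read at this place in this assay, and so whether compound 3, at 5100 nM, is an isolated case or part of a trend.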